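The source may report more compounds than this note shows. Statements on the series, on what has been measured and on what is new or still open speak of the compounds shown alone.

Measured so far in a functional assay for inhibition, with Homo sapiens as the target; a higher number here means a weaker inhibitor, a lower number a stronger inhibitor:

Compound 1, `Cc1cc2c(cc1C(=O)N=C(N)N)S(=O)(=O)CC2(C)O`, gives 115 nM.
Compound 2, `Cc1cc2c(cc1C(=O)N=C(N)N)S(=O)(=O)CC2C`, gives 182 nM.
Compound 3, `N=C(N)NC(=O)c1ccc2c(c1)S(=O)(=O)CC2O`, gives only a limit of the assay, > 100000 nM.

Compound 1 and compound 2 share one core and differ in a single place: hydrogen in place of hydroxy on a saturated ring carbon. That change made a 1.6-fold higher number from compound 1 to compound 2 (0.20 log units; within the scatter), so in this assay the two compounds cannot be told apart. Compound 3 is built on a different core; the difference between the two cores is not broken down here. Compound 3 sits at the limit of > 100000 nM in this assay, at which 1 of the 3 values shown sits.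

Compound 4, `N=C(N)NC(=O)c1ccc2c(c1)S(=O)(=O)CC2`, has not yet been measured. It stands to compound 3 as compound 2 stands to compound 1: hydrogen in place of hydroxy on a saturated ring carbon. The place of the change is described in the same words for both pairs, so this is the same change, made a second time on the other core. Because the like change gave a 1.6-fold higher number from compound 1 to compound 2 (0.20 log units; within the scatter), the step expected here is a step that the limit leaves unreadable from compound 3 to compound 4. Compound 4 is therefore expected at about 150000 nM, with a likely range from 30000 nM to 1000000 nM, and it will most likely again return only a limit rather than a number. Whether removing the hydroxy on this core behaves as it did on the core of compound 1 is exactly what the coming measurement of compound 4 will show.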

Compound 4, half-maximal inhibitory concentration: > 100000 nM
Compound 4: only a limit was reported; the forecaster's own chance of this, stated with the estimate: 75%; the middle value is on the limit's open side.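

Compound 3 and compound 4 both return only a limit in this assay and no size can be read for the step between them: the limit of > 100000 nM in this assay, at which 2 of the 4 values shown sit.

The compounds shown leave open whether hydrogen in place of hydroxy on a saturated ring carbon makes any difference on this core, as it could not be told from scatter on the core of compound 1.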